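The source may hold more compounds than are shown below. What is called first, only, known or untested is meant among the compounds shown, and "the series" means these compounds.

Compound 1 `O=C1O[C@H]([C@@H](O)Cn2cc(CNS(=O)(=O)c3ccc(F)cc3)nn2)C(OCc2ccccc2)=C1OCc1ccccc1`: in a functional assay on A549 cells (Homo sapiens) for antiproliferative activity, read by MTT assay, with a stated time of 72 h (a higher number here means a weaker inhibitor, a lower number a stronger inhibitor), compound 1 gives 22500 nM.
Compound 2 `O=C1O[C@H]([C@@H](O)Cn2cc(CCO)nn2)C(OCc2ccccc2)=C1OCc1ccccc1`: compound 2 gives > 100000 nM, which is a limit of the assay and not a number.
Compound 3 `Cc1ccc(-c2cn(C[C@H](O)[C@H]3OC(=O)C(OCc4ccccc4)=C3OCc3ccccc3)nn2)cc1`: compound 3 gives 8690 nM.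

Compound 3 holds the lowest of the two numbers shown, and the step of a 2.6-fold lower number from compound 1 to compound 3 (0.41 log units; beyond the scatter) separates it from its nearest neighbour beyond the scatter. Compound 4 `O=C1O[C@H]([C@@H](O)Cn2cc(CCCCl)nn2)C(OCc2ccccc2)=C1OCc1ccccc1` differs from compound 3 in one place: 3-chloropropyl in place of 4-methylphenyl on an aromatic carbon. Among the measured compounds shown here, two measured steps bear on this exchange of a ring for a short chain. The step of an at least 11-fold lower number from compound 2 to compound 3 (1.06 log units; beyond the scatter) shows that a chain on this carbon went with a far higher number than 4-methylphenyl, and a 2.6-fold lower number from compound 1 to compound 3 (0.41 log units; beyond the scatter) points the same way. A large upward step is therefore expected for compound 4, with a real chance that only a limit is reported. Compound 4 is expected to give 45000 nM, between 15000 nM and 150000 nM, a step of a 5.2-fold higher number from compound 3 to compound 4 (0.71 log units; beyond the scatter).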

Compound 4, half-maximal inhibitory concentration: 29000 nM
The estimate for compound 4 lay 1.6-fold (0.19 log units) above the measured number, and the stated range covers the measured number.
By their numbers in this assay, from the lowest: compound 3; then compounds 1 and 4 (each within the scatter of the next). At a limit, above all of these: compound 2.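

The step of a 3.3-fold higher number from compound 3 to compound 4 (0.52 log units; beyond the scatter) shows that a chain with no ring can still give a measurable number at this position, and a 1.3-fold higher number from compound 1 to compound 4 (0.11 log units; within the scatter) leaves 3-chloropropyl level with the side chain of compound 1. The end of the chain also counts, with chloromethyl in place of hydroxy: an at least 3.4-fold lower number from compound 2 to compound 4 (0.53 log units; beyond the scatter). For compound 2, the value is a limit and not a number: the limit of > 100000 nM in this assay, at which 1 of the 4 values shown sits.

Still open, as far as these compounds go, is how an amine or a carboxylic acid at the chain end, or a longer chain, would compare. Whether chlorine itself matters, or only the loss of hydroxy, also stays unsettled.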